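Swapping the cyanophenyl arm of a thienopyrimidine for fluoropyridyl

The compounds below may be only part of what the source reports. "The series", "measured", "known", "first", "only" and "open" are said of these compounds alone.

Measured compounds:
compound 1, `C=CS(=O)(=O)N1CCN(c2ncnc3sc(-c4ccc(C#N)cc4)cc23)CC1`, 8050 nM
compound 2, `C=CS(=O)(=O)N1CCN(c2ncnc3sc(-c4ccc(N5CCN(C)CC5)cc4)cc23)CC1`, 7550 nM

The assay is a functional assay on MDA-MB-231 cells (Homo sapiens) for antiproliferative activity, read by MTT assay, with a stated time of 48 h; on this read-out higher numbers stand for weaker inhibition and lower numbers for stronger inhibition. In this assay compound 1 gives 8050 nM, and compound 2 gives 7550 nM. Within the data shown here, compound 1 thus stands at one of only two numbers so far, and the scatter does not separate them: a 1.1-fold lower number from compound 1 to compound 2 (0.03 log units; within the scatter). That single step is the only one on record, and it concerns the same arm of the shared core that is now altered, since the cyano group is replaced there by 4-methylpiperazin-1-yl.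

The unmeasured compound 3 is `C=CS(=O)(=O)N1CCN(c2ncnc3sc(-c4ccc(F)nc4)cc23)CC1`. It differs from compound 1 as follows: 6-fluoropyridin-3-yl in place of 4-cyanophenyl on an aromatic carbon. Among the measured compounds shown here, the one measured step at this arm was small, so there is no basis for expecting a shift beyond the scatter, in either direction, in this assay. Compound 3 is therefore estimated at 8000 nM, with a range from 3000 nM to 22000 nM. The step this expectation implies, a 1.0-fold lower number from compound 1 to compound 3 (0.00 log units; within the scatter), is expected to stay inside the scatter.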

Compound 3, half-maximal inhibitory concentration: 16000 nM
For compound 3 the middle estimate is 2.0-fold (0.30 log units) below the measured one; low and high end bracket the measured number.
By their numbers in this assay, from the lowest: compounds 2, 1 and 3 (each within the scatter of the next, the first and the last beyond it).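

In this assay, the aromatic carbon next to the ring sulfur accepts a change of the ring itself, and not only of the group it carries: 6-fluoropyridin-3-yl in place of 4-cyanophenyl gives a 2.0-fold higher number from compound 1 to compound 3 (0.30 log units; within the scatter), so this step does not separate the two compounds. The three compounds do now show a first spread at this position, since compound 2 at 7550 nM and compound 3 at 16000 nM lie beyond the scatter of each other, while compound 1 lies within the scatter of both. No measurement available here accounts for the values at this position.

The fluoropyridyl arm changes the ring and its group at once, so the compounds shown cannot say whether the ring nitrogen or the fluorine matters more; a plain pyridin-3-yl and a 4-fluorophenyl at the same carbon would pull the two apart. Also open, as far as these compounds go, is whether any group at this carbon, such as a carboxylic acid or a primary amine on the phenyl ring, would move the number beyond the scatter of compound 1.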